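A few compounds are considered here, and "the series" means these few. Any claim that something is new, unique, unknown or untested is made for them only; others in the source may bear on it.

Measured compounds:
compound 1, `CCCCC#Cc1cncc(OC[C@@H]2CCN2)c1`, in an assay on HEK293 cells for displacement of a labelled ligand from Neuronal acetylcholine receptor; alpha4/beta2 (Rattus norvegicus), read by scintillation counting (on this read-out higher numbers stand for weaker inhibition and lower numbers for stronger inhibition), compound 1 gives 0.1 nM
compound 2, `[N-]=[N+]=NCCCCC#Cc1cncc(OC[C@@H]2CCN2)c1`, in this assay compound 2 gives 0.086 nM

Compound 1 and compound 2 share a core and differ only at the end of the saturated chain, where compound 2 carries an azido group. The step of a 1.2-fold lower number from compound 1 to compound 2 (0.07 log units; within the scatter) lies within the scatter, so the two numbers cannot be told apart; compound 1 stands at the upper end of this pair, but not by a margin that means anything.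

Compound 3, `CCCCC#Cc1cncc(OC[C@H]2CCCN2)c1`, has not yet been measured. It differs from compound 1 in one place: pyrrolidin-2-yl in place of azetidin-2-yl on a saturated chain carbon bound to an oxygen on an aromatic ring. Among the measured compounds shown here, no measured step touches this part of the molecule: the only step at hand, the one from compound 1 to compound 2, changes the chain end and leaves the ring untouched. The expectation for compound 3 therefore rests on the structural change alone, and a ring one carbon larger at this position is expected to give a higher number in this assay. Compound 3 is estimated at 1 nM, with a range from 0.2 nM to 5 nM. That estimate means a step of a 10-fold higher number from compound 1 to compound 3 (1.00 log units; beyond the scatter), expected to exceed the scatter.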

Compound 3, inhibition constant: 0.49 nM
The estimate for compound 3 lay 2.0-fold (0.31 log units) above the measured number; measured number inside the range.
By their numbers in this assay, from the lowest: compounds 2 and 1 (each within the scatter of the next); then compound 3.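

Moving from azetidin-2-yl to pyrrolidin-2-yl gives the first measured change on the saturated chain carbon bound to an oxygen on an aromatic ring, and in this assay it reads as a 4.9-fold higher number from compound 1 to compound 3 (0.69 log units; beyond the scatter). The azido group at the end of the chain left the number within the scatter, whereas this ring change moves it beyond the scatter, so this position responds to a change of ring size from four-membered to five-membered, although the step is modest and compound 3 still gives 0.49 nM. Nothing at hand bears on why the step has this size.

From the compounds shown here alone, two ring sizes cannot show whether the number would keep rising with a larger ring, so what a piperidin-2-yl group would give at this place stays open, as does the effect of a methyl group on the nitrogen of the ring. Going by these compounds, it is also open whether an azido group at the end of the chain would leave the number as little changed on the core of compound 3 as it does on the core of compound 1.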